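The compounds below may be only part of what the source reports. "The series", "measured", "known", "first", "only" and "open" are said of these compounds alone.

Compound 1 `N#Cc1ccccc1Cc1cnc(CCc2ccc(-c3ccccc3C(=O)O)cc2)[nH]1`: 642 nM
Compound 2 `CCCCc1cnc(/C=C/c2ccc(-c3ccccc3C(=O)O)cc2)[nH]1`: 10000 nM

Of the two compounds measured in an in vitro functional assay on cells for agonist activity at Bombesin receptor subtype-3 (Mus musculus), read by luminescence and calcium flux (on this read-out lower numbers stand for an effect already at smaller amounts and higher numbers for an effect only at larger amounts of compound), compound 1 holds the lower number; compound 2 sits well above it, and that gap lies beyond the usual scatter. Compound 3 `CC(C)CCc1cnc(CCc2ccc(-c3ccccc3C(=O)O)cc2)[nH]1` is still unmeasured. It differs from compound 1 in one place: isobutyl in place of 2-cyanophenyl on a saturated chain carbon bound to an aromatic carbon. Within the data shown here, no measured pair shows this same change, so its size cannot be read off from existing data; it can only be expected. The aromatic group with its nitrile gives way to a short branched chain, and the account treats this as a change that likely costs something rather than nothing. In this assay the step is expected to be a modest one of a 4.7-fold higher number from compound 1 to compound 3 (0.67 log units; beyond the scatter). Compound 3 is therefore estimated at 3000 nM, with a range from 800 nM to 12000 nM.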

Compound 3, half-maximal effective concentration: 10 nM
Estimate against measurement, compound 3: 300-fold (2.48 log units) above, and the stated range ends above it.
By their numbers in this assay, from the lowest: compound 3; then compound 1; then compound 2.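

In this assay, replacing 2-cyanobenzyl with isopentyl on the shared core gives a 64-fold lower number from compound 1 to compound 3 (1.81 log units; beyond the scatter), so a low number at this position does not depend on the 2-cyanophenyl group or its nitrile. An open chain with no ring and no hydrogen-bond acceptor can stand here, which compound 1 and compound 2 could not show, as they differ in more than one place. Nothing available explains why the number drops so far.

As far as these compounds go, whether the branching of the isopentyl group matters remains open, and a straight pentyl chain or a longer chain would address that question. From the compounds shown here alone, it also remains open whether a plain benzyl or cyclohexylmethyl group, or a chain carrying an amine, would keep a number as low as that of compound 3 at 10 nM.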